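The compounds below may be only part of what the source reports. "The series", "measured", "known", "first", "only" and "open" are said of these compounds alone.

Of the compounds shown here, three built on one shared core have been tested in a functional assay on K562 cells (Homo sapiens) for inhibition, read by sulforhodamine B assay, with a stated time of 48 h; a lower number here means a stronger inhibitor of growth, a higher number a weaker inhibitor of growth. Compound 1, `CC(C)(C)NCc1c(C(=O)O)nn(-c2ccccc2)c1-c1ccc(F)cc1`, gives in this assay only a limit of the measurement, > 680000 nM, which is the limit of > 680000 nM in this assay, at which 1 of the 3 values shown sits. Compound 3, `CC(C)(C)NCc1c(C(=O)O)nn(-c2ccccc2)c1-c1ccccc1`, likewise gives in this assay only a limit, > 716000 nM, which is the limit of > 716000 nM in this assay, at which 1 of the 3 values shown sits. The two cores differ by fluoro in place of hydrogen on an aromatic carbon. Compound 2, `CC(C)(C)NCc1c(C(=O)O)nn(-c2ccccc2)c1-c1ccc(Cl)cc1`, gives in this assay 364000 nM. The change from compound 3 to compound 2 is chloro in place of hydrogen on an aromatic carbon, and the step it made is an at least 1.9-fold lower number from compound 3 to compound 2 (0.29 log units; that floor lies within the scatter). Among the measured compounds shown here, compound 4, `CC(C)(C)NCc1c(C(=O)O)nn(-c2ccc(Cl)cc2)c1-c1ccc(F)cc1`, is not yet measured; it differs from compound 1 by chloro in place of hydrogen on an aromatic carbon, which is the same change as the one from compound 3 to compound 2, in surroundings described in the same words.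

The step from compound 1 to compound 4 is expected to be an at least 1.7-fold lower number from compound 1 to compound 4 (0.23 log units; that floor lies within the scatter), resting on the step of an at least 1.9-fold lower number from compound 3 to compound 2 (0.29 log units; that floor lies within the scatter) and on the limit that compound 1 shows. Compound 4 is therefore estimated at 400000 nM, between 150000 nM and 1000000 nM, with a real chance that only a limit is recorded again.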

Compound 4, concentration for 50% growth inhibition: > 623000 nM
Compound 4: no number, only a limit; the forecaster's own chance of this, stated with the estimate: 45%; at least 1.5-fold (0.19 log units) between middle value and limit.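

Compound 1 and compound 4 each give only a limit of the assay, not a number, and the step between them cannot be read. The compounds shown leave open whether the change from phenyl to 4-chlorophenyl on the core of compound 1 alters growth inhibition at all, and in which direction.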